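The compounds below may be only part of what the source reports. "The series", "measured", "known", "first", "only" and "open" are said of these compounds alone.

Of the compounds shown here, two have been measured in an assay on isolated protein for inhibition of Deoxynucleoside kinase (Drosophila melanogaster) (on this read-out higher numbers stand for weaker inhibition and lower numbers for stronger inhibition), so far, and both share the same core. Compound 1 `COCC(=O)O[C@H]1[C@H](O)[C@@H](CO)O[C@H]1n1cc(/C=C/Br)c(=O)[nH]c1=O` gives 215000 nM in this assay. Compound 2 `CC(C)(C)OC(=O)NCCCCCC(=O)O[C@H]1[C@H](O)[C@@H](CO)O[C@H]1n1cc(/C=C/Br)c(=O)[nH]c1=O` gives 77000 nM in this assay. Among the compounds with values here, compound 2 therefore stands at the lower of the two numbers, and its only neighbour, compound 1, sits beyond the scatter above it; no single-point comparison between the two is available, so their values show only that compound 2 is the stronger inhibitor of the pair.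

Compound 3 `NCCCCCC(=O)O[C@H]1[C@H](O)[C@@H](CO)O[C@H]1n1cc(/C=C/Br)c(=O)[nH]c1=O` has not yet been measured. It differs from compound 2 by hydrogen in place of tert-butoxycarbonyl on an amine nitrogen, which leaves the amine nitrogen bearing only hydrogen on a saturated chain carbon. No measured pair among these compounds tests a change of this kind, so nothing in the data fixes its size or direction. The step from compound 2 is expected to be small, within or only modestly beyond the scatter, as a 1.4-fold higher number from compound 2 to compound 3 (0.15 log units; within the scatter). In this assay compound 3 is expected to give about 110000 nM, with a range from 35000 nM to 350000 nM.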

Compound 3, half-maximal inhibitory concentration: > 500000 nM
Compound 3 ended at the assay's limit (the forecaster's own chance of this, stated with the estimate: 10%); middle value at least 4.5-fold (0.65 log units) from the limit.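

Compound 3 stands at a limit of this assay and not at a number: the limit of > 500000 nM in this assay, at which 1 of the 3 values shown sits. At this position, the amine nitrogen on a saturated chain carbon, hydrogen in place of tert-butoxycarbonyl gives an at least 6.4-fold higher number from compound 2 to compound 3 (0.81 log units; beyond the scatter), so the change is far from silent, and its printed size is only a lower bound. With 4-aminobutyl in place of methoxy on a saturated chain carbon bound to a carbonyl carbon, the data show an at least 2.3-fold higher number from compound 1 to compound 3 (0.36 log units; beyond the scatter), so the amine-ended chain of compound 3 also falls behind the methoxy-bearing ester of compound 1, and the chain shared by compound 2 and compound 3 does not by itself keep the inhibition seen for compound 2.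

The compounds shown leave open whether the gain depends on the whole tert-butoxycarbonyl group or only on some acyl group on that nitrogen, as an acetyl amide or a methyl carbamate would test. They also leave open how a carboxylic acid or a hydroxyl at the chain end, or a shorter or longer chain carrying the same tert-butoxycarbonyl amine, would read in this assay.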